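A few compounds are considered here, and "the series" means these few. Any claim that something is new, unique, unknown or untested is made for them only; others in the source may bear on it.

Measured compounds:
compound 1, `C/C(=C\c1cc(-c2ccc(C)nc2)co1)C(N)=O`: > 50000 nM
compound 2, `C/C(=C\c1ccc(-c2ccc(C)cc2)o1)C(N)=O`: > 50000 nM
compound 3, `C/C(=C\c1cc(-c2ccc(F)cc2)cs1)C(N)=O`: > 50000 nM

All three were tested in an ADME assay on NIH3T3 cells (Mus musculus) for cytotoxicity, read by CCK-8 assay, with a stated time of 24 h; a higher number here means a weaker inhibitor, a lower number a stronger inhibitor. For compound 1 the result is only a limit, > 50000 nM. For compound 2 the result is again a limit, > 50000 nM. Compound 3 likewise reached only a limit, > 50000 nM. Compound 3 therefore stands exactly where the two others stand, at the limit of > 50000 nM in this assay, at which 3 of the 3 values shown sit; no number separates it from compound 1 or compound 2, and nothing can be said about an order among the three.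

Compound 4 `C/C(=C\c1cc(-c2ccc([N+](=O)[O-])cc2)cs1)C(N)=O` is not yet measured. Compared with compound 3 it carries nitro in place of fluoro on an aromatic carbon, that is, nitro in place of fluoro on an aromatic carbon. Going by the values given here, no step between two measured compounds is known here, so there is no measured change to lean on. The expectation is that this change makes no step beyond the scatter in either direction, given that every measured compound sits at the limit of > 50000 nM in this assay, at which 3 of the 3 values shown sit, and that the measurement will most likely again end at the limit. The estimate for compound 4 is 50000 nM, within 20000 nM to 120000 nM, which means an expected step of a number no higher from compound 3 to compound 4 (the limit leaves the size open) of essentially none.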

Compound 4, half-maximal inhibitory concentration: > 50000 nM
Compound 4: no number, only a limit; the forecaster's own chance of this, stated with the estimate: 85%; the middle value sits exactly at the limit.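

Compound 4, like compound 3, gives only a limit in this assay, so no step can be read between compound 3 and compound 4. The compounds shown leave open whether any change on this series alters the result, since all four values sit at one limit: the limit of > 50000 nM in this assay, at which 4 of the 4 values shown sit.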